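Removing One Methoxy Group: What Growth Inhibition May Follow

The compounds below may be only part of what the source reports. "The series", "measured", "known", "first", "only" and "open" are said of these compounds alone.

Compound 1 `COc1ccc(-c2cc(/C=C/C(=O)c3ccc(N)cc3)[nH]n2)cc1`: 10600 nM in a functional assay on ACHN cells (Homo sapiens) for inhibition, read by sulforhodamine B assay, with a stated time of 48 h; on this read-out higher numbers stand for weaker inhibition of growth and lower numbers for stronger inhibition of growth
Compound 2 `COc1cc(-c2cc(/C=C/C(=O)c3ccc(N)cc3)[nH]n2)cc(OC)c1OC`: 3670 nM in this assay

Compound 2 gives the lowest number of the two, and compound 1 sits clearly above it, beyond the usual scatter. Compound 3 `COc1ccc(-c2cc(/C=C/C(=O)c3ccc(N)cc3)[nH]n2)cc1OC` differs from compound 2 in one place: hydrogen in place of methoxy on an aromatic carbon, leaving two methoxy groups on that ring. For the measured compounds named here, no measured pair isolates this change, so its direction is uncertain; because compound 1, carrying a single methoxy group, gives 10600 nM, a modest rise in number is expected, a 1.5-fold higher number from compound 2 to compound 3 (0.18 log units; within the scatter). Compound 3 is therefore estimated at 5500 nM, with a likely range from 2000 nM to 15000 nM.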

Compound 3, concentration for total growth inhibition: 3290 nM
The estimate for compound 3 lay 1.7-fold (0.22 log units) above the measured number, within the range that was stated.
By their numbers in this assay, from the lowest: compounds 3 and 2 (each within the scatter of the next); then compound 1.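

In this assay, the methoxy group ortho to a methoxy group can be replaced by hydrogen with the change staying within the scatter (a 1.1-fold lower number from compound 2 to compound 3 (0.05 log units; within the scatter)), so this group makes no measurable difference here. The clear step comes instead from adding a second methoxy group to the ring of compound 1 (a 3.2-fold lower number from compound 1 to compound 3 (0.51 log units; beyond the scatter)). Nothing available explains either step. Still open, going by these compounds, is whether a hydroxyl group, a fluorine atom or an amine on this same carbon would match hydrogen or methoxy, and whether a longer alkoxy chain would be tolerated there.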